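The compounds below may be only part of what the source reports. "The series", "measured", "known", "first", "only" and "open" are said of these compounds alone.

Measured so far in a functional assay on MCF7 cells (Homo sapiens) for antiproliferative activity, read by CellTiter-Glo, with a stated time of 5 days (a higher number here means a weaker inhibitor, a lower number a stronger inhibitor), are three compounds:

Compound 1 (`O=C(O)/C=C/c1ccc(/C(=C(\c2ccc(F)cc2Cl)C2CCC2)c2ccc3scnc3c2)cc1`) at 3 nM
Compound 2 (`N#Cc1cc(Cl)ccc1/C(=C(\c1ccc(/C=C/C(=O)O)cc1)c1ccc2scnc2c1)C1CCC1`) at 0.9 nM
Compound 3 (`O=C(O)/C=C/c1ccc(/C(=C(\c2ccc(C(F)(F)F)cc2Cl)C2CCC2)c2ccc3scnc3c2)cc1`) at 2.6 nM

Compound 3 belongs to the upper pair of these three numbers. Within that pair the gap is a 1.2-fold lower number from compound 1 to compound 3 (0.06 log units; within the scatter) and separates nothing, while the gap to the remaining compound is a 2.9-fold higher number from compound 2 to compound 3 (0.46 log units; beyond the scatter) and modest.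

Compound 4 (`O=C(O)/C=C/c1ccc(/C(=C(\c2ncc(C(F)(F)F)cc2Cl)C2CCC2)c2ccc3scnc3c2)cc1`) departs from compound 3 in one group (3-chloro-5-(trifluoromethyl)pyridin-2-yl in place of 2-chloro-4-(trifluoromethyl)phenyl on a double-bonded chain carbon bound to a double-bonded chain carbon and a saturated ring carbon) and carries 3-chloro-5-(trifluoromethyl)pyridin-2-yl in place of 2-chloro-4-(trifluoromethyl)phenyl. The group sits on a double-bonded chain carbon bound to a double-bonded chain carbon and a saturated ring carbon.

The swaps at this same place were small: a 3.3-fold lower number from compound 1 to compound 2 (0.52 log units; beyond the scatter) was modest, and the two gaps above were no larger. None of them brings in a ring with a hetero atom, so the data offer no direct measure of this change. No step beyond the scatter is therefore expected in this assay and no direction is favoured. The expected step is a 1.3-fold higher number from compound 3 to compound 4 (0.13 log units; within the scatter) and nothing more. For compound 4 the estimated value is 3.5 nM with an expected range from 1.2 nM to 10 nM in this test.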

Compound 4, half-maximal inhibitory concentration: 2.9 nM
Compound 4: middle estimate off by 1.2-fold (0.08 log units), on the high side; the measured number falls inside the stated range.
By their numbers in this assay, from the lowest: compound 2; then compounds 3, 4 and 1 (each within the scatter of the next).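

In this assay, the only ring with a hetero atom at this place, the 3-chloro-5-(trifluoromethyl)pyridin-2-yl group, replaces 2-chloro-4-(trifluoromethyl)phenyl with a 1.1-fold higher number from compound 3 to compound 4 (0.05 log units; within the scatter), so a ring nitrogen on this double-bonded chain carbon is tolerated. The comparison with the 2-chloro-4-fluorophenyl group gives the same picture (a 1.0-fold lower number from compound 1 to compound 4 (0.01 log units; within the scatter)), whereas the 4-chloro-2-cyanophenyl group remains apart from the new ring (a 3.2-fold higher number from compound 2 to compound 4 (0.51 log units; beyond the scatter)), and it alone among these four stands beyond the scatter. Nothing measured here explains why the ring nitrogen makes no visible difference.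

From the compounds shown here alone, whether a nitrile in place of the trifluoromethyl on the pyridin-2-yl ring would match the 4-chloro-2-cyanophenyl group stays open. So does the outcome with a second ring nitrogen or an amine on this ring.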